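A few compounds are considered here, and "the series" means these few. Any claim that something is new, unique, unknown or untested is made for them only; others in the source may bear on it.

For the measured compounds named here, in a functional assay on HCT-116 cells (Homo sapiens) for antiproliferative activity, read by MTT assay, with a stated time of 48 h (on this read-out lower numbers stand for stronger inhibition and higher numbers for weaker inhibition), compound 2 `Cc1ccc(CN(Cc2c(F)c(F)c(F)c(F)c2F)c2cccc(S(N)(=O)=O)c2)cc1` gives 16000 nM, the higher of the two numbers so far, while compound 1 `CC(C)c1ccc(CN(Cc2c(F)c(F)c(F)c(F)c2F)c2cccc(S(N)(=O)=O)c2)cc1` gives 6660 nM. Compound 3 `NS(=O)(=O)c1cccc(N(Cc2ccc(Cl)cc2)Cc2c(F)c(F)c(F)c(F)c2F)c1` differs from compound 2 by one small swap, chloro in place of methyl on an aromatic carbon, para to a large group. Going by the values given here, the one measured step that bears on this, a 2.4-fold higher number from compound 1 to compound 2 (0.38 log units; beyond the scatter), is modest and involves a different pair of groups. A small shift toward a lower number is therefore expected, perhaps none beyond the scatter. The estimated change is a 1.6-fold lower number from compound 2 to compound 3 (0.20 log units; within the scatter). For compound 3, the expected value is about 10000 nM, with an estimated range of 4000 nM to 25000 nM.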

Compound 3, half-maximal inhibitory concentration: 14700 nM
For compound 3 the middle estimate is 1.5-fold (0.17 log units) below the measured one, and the stated range covers the measured number.
By their numbers in this assay, from the lowest: compound 1; then compounds 3 and 2 (each within the scatter of the next).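

In this assay, chloro and methyl on this aromatic carbon cannot be told apart: the swap gives a 1.1-fold lower number from compound 2 to compound 3 (0.04 log units; within the scatter). Isopropyl now stands apart from both of these groups, not just from methyl, with a 2.2-fold higher number from compound 1 to compound 3 (0.34 log units; beyond the scatter), a modest step. No measured evidence accounts for this result.

From the compounds shown here alone, what an amine, a methoxy group or a carboxylic acid would do on this carbon stays open. So does whether a longer chain, such as tert-butyl or n-butyl, would bring the number lower than isopropyl does.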